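From 4-aminophenyl to 2-methylphenyl on the shared core

The source may report more compounds than this note shows. Statements on the series, on what has been measured and on what is new or still open speak of the compounds shown alone.

Of the compounds shown here, two have been measured so far in a functional assay on HL-60 cells (Homo sapiens) for cytotoxicity, read by MTT assay, with a stated time of 48 h; on this read-out lower numbers stand for stronger inhibition and higher numbers for weaker inhibition. In this assay compound 1 (`Fc1cccc(-c2nc(Nc3ccccc3)c3cc(F)ccc3n2)c1`) gives 48300 nM, close to the top of the measurable range. Compound 2 (`Nc1ccc(Nc2nc(-c3cccc(F)c3)nc3ccc(F)cc23)cc1`) stands at > 50000 nM, which is a limit of the assay and not a number.

The next compound is compound 3 (`Cc1ccccc1Nc1nc(-c2cccc(F)c2)nc2ccc(F)cc12`), with 2-methylphenyl in place of 4-aminophenyl on a nitrogen on an aromatic ring.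

Among the measured compounds shown here, only one measured step bears on this change: an at least 1.0-fold higher number from compound 1 to compound 2 (0.01 log units; that floor lies within the scatter). That step is a floor within the scatter, so it shows no clear effect of the amino group. Compound 3 has no amino group, as is also true of compound 1, so the expectation rests on compound 1 at 48300 nM. The methyl group has not been tested in this series.

A value near that of compound 1 is expected, or another limit. The expected change is small and toward lower numbers: an at least 1.1-fold lower number from compound 2 to compound 3 (0.07 log units; that floor lies within the scatter). The estimated value for compound 3 is 42000 nM, within an expected range of 18000 nM to 90000 nM.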

Compound 3, half-maximal inhibitory concentration: > 50000 nM
Compound 3 was reported as a limit; the forecaster's own chance of this, stated with the estimate: 45%; middle value at least 1.1-fold (0.07 log units) from the limit.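

In this assay compound 3 sits at a limit and not a number, as compound 2 does, so the change from 4-aminophenyl to 2-methylphenyl on a nitrogen on an aromatic ring cannot be read. The step that can be read is the addition of the methyl group, with an at least 1.0-fold higher number from compound 1 to compound 3 (0.01 log units; that floor lies within the scatter) and so no clear effect of the methyl group. Neither the amino group of compound 2 nor the methyl group of compound 3 gives a readable step beyond the scatter from compound 1, and the values gather at the top of the range: the limit of > 50000 nM in this assay, at which 2 of the 3 values shown sit.

Open, from the compounds shown here alone, is whether any group on this ring can bring a number clearly lower than that of compound 1 at 48300 nM in this series. A carboxylic acid, a methoxy group or a longer chain on that ring would show whether the read-out can move away from the limit at all, since the amine and the methyl group shown leave that question untouched.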